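A few compounds are considered here, and "the series" means these few. Any claim that something is new, unique, unknown or untested is made for them only; others in the source may bear on it.

Measured so far:
- compound 1 `N[C@@H](CC(=O)OC[C@H]1O[C@@H](n2cc(F)c(=O)[nH]c2=O)C[C@@H]1O)C(=O)O`: 0.185 h
- compound 2 `N[C@@H](CC(=O)OC[C@H]1O[C@@H](n2cc(F)c(=O)[nH]c2=O)C[C@@H]1OC(=O)C[C@H](N)C(=O)O)C(=O)O`: 0.155 h
- compound 3 `CC(C)[C@H](N)C(=O)OC[C@H]1O[C@@H](n2cc(F)c(=O)[nH]c2=O)C[C@@H]1OC(=O)[C@@H](N)C(C)C`: 0.168 h

In an ADME assay on tissue (MDA-MB-231 cells, Homo sapiens) for pharmacokinetics (on this read-out higher numbers stand for a longer-lived compound and lower numbers for a shorter-lived compound), compound 1 gives 0.185 h, a value within the scatter of those of both compound 2 and compound 3. The unmeasured compound 4 `N[C@@H](CCC(=O)OC[C@H]1O[C@@H](n2cc(F)c(=O)[nH]c2=O)C[C@@H]1O)C(=O)O` keeps the core of compound 1 but carries 2-amino-2-carboxyethyl in place of amino(carboxy)methyl on a saturated chain carbon bound to a carbonyl carbon. Cut one bond further out, the same difference reads 2-amino-2-carboxyethyl to 3-amino-3-carboxypropyl.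

Among the measured compounds shown here, no measured step makes this exact change. For the measured compounds named here, the only single-place step available is a 1.2-fold lower number from compound 1 to compound 2 (0.08 log units; within the scatter), which lies within the scatter, although it adds a whole acyl group at another oxygen. A smaller change in the chain is therefore not expected to move this assay beyond the scatter, in either direction. The expected step is a 1.0-fold lower number from compound 1 to compound 4 (0.01 log units; within the scatter). For compound 4 the estimated half-life is 0.18 h, with an expected range from 0.11 h to 0.3 h.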

Compound 4, half-life: 0.288 h
Compound 4: middle estimate off by 1.6-fold (0.20 log units), on the low side, and the stated range covers the measured number.
By their numbers in this assay, from the lowest: compounds 2, 3, 1 and 4 (each within the scatter of the next).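

The earlier step changed compound 1 only at another oxygen, whereas this one alters the ester chain itself, on a saturated chain carbon bound to a carbonyl carbon, and leaves the rest of compound 1 in place. In this assay, replacing amino(carboxy)methyl with 2-amino-2-carboxyethyl gives a 1.6-fold higher number from compound 1 to compound 4 (0.19 log units; within the scatter), so this single step does not separate the two chain lengths, and all four compounds still form a series in which each lies within the scatter of the next. No supporting data given here bear on this result.

The compounds shown leave open whether a longer chain than 3-amino-3-carboxypropyl would move the half-life beyond the scatter. They also leave open what would happen at this place with a chain ending in an amine alone or in a carboxylic acid alone.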